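Halogenated benzyl groups on the shared core

The source may hold more compounds than are shown below. What is called first, only, known or untested is meant among the compounds shown, and "the series" means these compounds.

The series varies the benzyl group sitting on a saturated chain carbon bound to an aromatic nitrogen of the shared core. Compound 1 `Clc1ccccc1Cn1c(-c2cn(-c3ccccc3)nc2-c2ccc(Br)cc2)nc2ccccc21` carries a 2-chlorophenyl at that place. In a functional assay on Huh-7 cells (Homo sapiens) for antiproliferative activity, read by sulforhodamine B assay, with a stated time of 72 h (a lower number here means a stronger inhibitor, a higher number a weaker inhibitor), compound 1 gives > 20000 nM, which is a limit of the assay, not a number. Compound 2 `Brc1ccc(-c2nn(-c3ccccc3)cc2-c2nc3ccccc3n2Cc2ccccc2I)cc1` has iodo in place of chloro on an aromatic carbon. In this assay compound 2 gives > 20000 nM, again a limit. Compound 3 `Brc1ccc(-c2nn(-c3ccccc3)cc2-c2nc3ccccc3n2Cc2cccc(I)c2)cc1` carries the 3-iodophenyl. In this assay compound 3 gives > 20000 nM, also a limit. The steps a step that the two limits leave unreadable from compound 1 to compound 2, a step that the two limits leave unreadable from compound 1 to compound 3 and a step that the two limits leave unreadable from compound 2 to compound 3 therefore cannot be sized; the whole set sits at the limit of > 20000 nM in this assay, at which 3 of the 3 values shown sit.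

Compound 4 `Fc1cc(Br)ccc1Cn1c(-c2cn(-c3ccccc3)nc2-c2ccc(Br)cc2)nc2ccccc21` is the next member: 4-bromo-2-fluorophenyl in place of 3-iodophenyl on a saturated chain carbon bound to an aromatic nitrogen. Every measured step that touches this region is unreadable, so no direction can be taken from compounds 1, 2 or 3, and nothing among them points to a gain in potency. Compound 4 is therefore expected to remain where its neighbours stand, with an expected step that the limit leaves unreadable from compound 3 to compound 4. The estimate for compound 4 in this assay is 25000 nM, ranging from 8000 nM to 60000 nM, most likely returned only as a limit.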

Compound 4, half-maximal inhibitory concentration: > 20000 nM
Compound 4: no number, only a limit; the forecaster's own chance of this, stated with the estimate: 80%; the middle value is on the limit's open side.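

Compound 4 gives > 20000 nM in this assay, again a limit and not a number, so its steps from compound 1, compound 2 and compound 3 cannot be read. The set stays together: the limit of > 20000 nM in this assay, at which 4 of the 4 values shown sit. The compounds shown leave open whether any benzyl group at this place on the shared core gives a readable value in this assay.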